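This account rests on a few compounds, and the source may have more. Where it says the series, first, only, none or still open, it means among the compounds named here.

Three compounds from this series have an entry in an ADME assay on Caco-2 cells (Homo sapiens) for permeability, in the apical to basolateral direction (on this read-out lower numbers stand for lower permeability and higher numbers for higher permeability), together with a fourth that has none yet. Compound 1, `CC(=O)N1CCN(c2cccc(-c3cc(-c4cc(C(C)C)no4)c4c(N)ncnn34)c2)C(=O)C1(C)C`, carries the largest substituent on the shared core, but in this assay compound 1 gives "not determined" (no result reported). Compound 2, `CC(=O)N1CCN(c2cccc(-c3cc(C#N)c4c(N)ncnn34)c2)C(=O)C1(C)C`, carries a nitrile at that position and in this assay compound 2 gives 84 nm/s. Compound 3, `CC(=O)N1CCN(c2cc(-c3cc(Cl)c4c(N)ncnn34)ccc2C(F)(F)F)C(=O)C1(C)C`, carries a chlorine on the core and a trifluoromethyl on the attached benzene ring, and in this assay compound 3 gives 150 nm/s. The two numbers for compound 2 and compound 3 fall within the usual scatter of each other, so neither compound can be said to permeate better than the other; compound 3 simply stands at one of two nearly equal values.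

Compound 4, `CC(=O)N1CCN(c2cc(-c3cc(Cl)c4c(N)ncnn34)ccc2C(C)O)C(=O)C1(C)C`, keeps everything in compound 3 except for one change: 1-hydroxyethyl in place of trifluoromethyl on an aromatic carbon. Within the data shown here, no pair of measured compounds differing in a single place is available, so the size of this step can only be estimated. The entering group brings hydrogen-bond donor and acceptor character that trifluoromethyl lacks, and the step from compound 3 to compound 4 is expected to be a decrease of a 2.5-fold lower number from compound 3 to compound 4 (0.40 log units; beyond the scatter), likely beyond the scatter. Compound 4 is therefore estimated at 60 nm/s, within a range of 25 nm/s to 150 nm/s.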

Compound 4, apparent permeability: 31 nm/s
Estimate against measurement, compound 4: 1.9-fold (0.29 log units) above; the measured number falls inside the stated range.
By their numbers in this assay, from the lowest: compound 4; then compounds 2 and 3 (each within the scatter of the next).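

In this assay, putting 1-hydroxyethyl in place of trifluoromethyl on this aromatic carbon, ortho to a large group and para to a large group, gives a 4.8-fold lower number from compound 3 to compound 4 (0.68 log units; beyond the scatter). Among these compounds, this is the first single-place comparison, and it shows that the number read in this assay is not indifferent to the group at this position. The entering group has a hydrogen-bond donor and a hydrogen-bond acceptor while the group it replaces has neither, but nothing measured here accounts for the lower number, and one pair cannot show which difference between the two groups matters.

Going by these compounds, it remains open where a plain ethyl chain, an amine or a carboxylic acid on this same carbon would fall relative to compound 3 and compound 4, and such groups could help separate the contribution of the oxygen from that of the carbon chain. Also open, on these data alone, is whether the same exchange would give a step of similar size on a core carrying a nitrile, as compound 2 does, rather than the chlorine of compound 3.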